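A few compounds are considered here, and "the series" means these few. Any claim that something is new, unique, unknown or untested is made for them only; others in the source may bear on it.

Compound 3 `CCOC(=O)c1cn(C)c2cc(Cl)ccc2c1=O` carries only a methyl on the aromatic nitrogen of the shared core. In a functional assay on PC-3 cells (Homo sapiens) for cytotoxicity, read by MTT assay, with a stated time of 24 h (a lower number here means a stronger inhibitor, a higher number a weaker inhibitor), compound 3 gives > 50000 nM, which is a limit of the assay and not a number. Compound 2 `C=CCn1cc(C(=O)OCC)c(=O)c2ccc(Cl)cc21` likewise sits at a limit, giving > 50000 nM in this assay. Compound 1 `CCOC(=O)c1cn(CCCc2ccccc2)c2cc(Cl)ccc2c1=O`, whose chain on that nitrogen ends in a phenyl, gives 16100 nM in this assay. The steps of an at least 3.1-fold higher number from compound 1 to compound 2 (0.49 log units; beyond the scatter) and an at least 3.1-fold higher number from compound 1 to compound 3 (0.49 log units; beyond the scatter) both point to weaker inhibition once the phenyl-bearing chain is gone, whereas a step that the two limits leave unreadable from compound 2 to compound 3 cannot be read because of the limit of > 50000 nM in this assay, at which 2 of the 3 values shown sit. Compound 4 `CCCCn1cc(C(=O)OCC)c(=O)c2ccc(Cl)cc21` differs from compound 3 by propyl in place of hydrogen on a saturated chain carbon bound to an aromatic nitrogen. Compound 2, whose chain on the nitrogen is of similar length, stayed at the limit. No chain without a phenyl has yet given a number. Compound 4 is therefore expected to shift by an at least 1.2-fold lower number from compound 3 to compound 4 (0.09 log units; that floor lies within the scatter) in this assay at most, staying weak. For compound 4 the estimate is 40000 nM, with a range from 15000 nM to 110000 nM.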

Compound 4, half-maximal inhibitory concentration: 41700 nM
Compound 4: the middle estimate sits 1.0-fold (0.02 log units) below what was measured; low and high end bracket the measured number.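

In this assay, among the compounds shown here, compound 4 is the first compound without a phenyl on the chain to give a number and not a limit, so a plain butyl on the aromatic nitrogen is enough for a readable value. Its step to the phenyl-ended chain is also readable and isolates the chain end: a 2.6-fold higher number from compound 1 to compound 4 (0.41 log units; beyond the scatter), with methyl in place of phenyl three bonds along the chain from the aromatic nitrogen. In the other direction only floors can be read, an at least 1.1-fold lower number from compound 3 to compound 4 (0.07 log units; that floor lies within the scatter) and an at least 1.1-fold lower number from compound 2 to compound 4 (0.07 log units; that floor lies within the scatter), and both lie within the scatter, so neither establishes a change: the limit of > 50000 nM in this assay, at which 2 of the 4 values shown sit.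

From the compounds shown here alone, whether a longer chain such as octyl, or an amine at the chain end, would move the number further remains open. The compounds also leave open how a carboxylic acid in place of the ethyl ester would read.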